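Ortho chloro added to the para-chlorophenyl of compound 3

This account rests on a few compounds, and the source may have more. Where it says the series, first, only, none or still open, it means among the compounds named here.

Measured compounds: compound 1 `COc1cc2c(Oc3ccc(NC(=O)c4nn(-c5ccccc5C)c(=O)cc4C)cc3F)ccnc2cc1OCCCN1CCCCC1` with 1920 nM; compound 2 `COc1cc2c(Oc3ccc(NC(=O)c4nn(-c5cccc(F)c5)c(=O)cc4C)cc3F)ccnc2cc1OCCCN1CCCCC1` with 250 nM; compound 3 `COc1cc2c(Oc3ccc(NC(=O)c4nn(-c5ccc(Cl)cc5)c(=O)cc4C)cc3F)ccnc2cc1OCCCN1CCCCC1` with 320 nM, all in a functional assay on A549 cells (Homo sapiens) for inhibition, read by MTT assay, with a stated time of 72 h; a higher number here means a weaker inhibitor, a lower number a stronger inhibitor.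

Compound 3 stands second highest of the three numbers in this assay, with compound 2 closest and compound 1 furthest. Compound 4 `COc1cc2c(Oc3ccc(NC(=O)c4nn(-c5ccc(Cl)cc5Cl)c(=O)cc4C)cc3F)ccnc2cc1OCCCN1CCCCC1` differs from compound 3 by chloro in place of hydrogen on an aromatic carbon. For the measured compounds named here, no measured step adds a substituent to an already substituted phenyl; the steps that come nearest are a 6.0-fold lower number from compound 1 to compound 3 (0.78 log units; beyond the scatter) and a 1.3-fold higher number from compound 2 to compound 3 (0.11 log units; within the scatter), where only the ring substitution pattern changes. Since the ring with an ortho group, compound 1, gives the highest number, a rise beyond the scatter is expected for compound 4, estimated as a 2.2-fold higher number from compound 3 to compound 4 (0.34 log units; beyond the scatter), giving 700 nM with a range from 250 nM to 2000 nM.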

Compound 4, half-maximal inhibitory concentration: 220 nM
For compound 4 the middle estimate is 3.2-fold (0.50 log units) above the measured one; measured number outside the range, below it.
By their numbers in this assay, from the lowest: compounds 4, 2 and 3 (each within the scatter of the next); then compound 1.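

In this assay, chloro in place of hydrogen on an aromatic carbon, ortho to a large group, is tolerated: the change gives a 1.5-fold lower number from compound 3 to compound 4 (0.16 log units; within the scatter) and the comparison with the 3-fluorophenyl ring gives a 1.1-fold lower number from compound 2 to compound 4 (0.06 log units; within the scatter). A group at this place therefore does not in itself bring the high number of compound 1, as 2,4-dichlorophenyl in place of 2-methylphenyl gives an 8.7-fold lower number from compound 1 to compound 4 (0.94 log units; beyond the scatter). No measurement at hand explains this result.

The compounds shown leave open whether methyl, methoxy or an amine at this place, alongside the 4-chloro group, would hold the number of compound 4.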